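A few compounds are considered here, and "the series" means these few. Any claim that something is new, unique, unknown or untested is made for them only; others in the source may bear on it.

Compound 1 `COc1cc(/C=C/C(=O)c2cccc(NC(=O)c3ccc(Cl)cc3)c2)ccc1O`: 2.3 ug/mL
Compound 2 `COc1cc(/C=C/C(=O)c2cccc(NC(=O)c3ccco3)c2)ccc1O`: 0.76 ug/mL
Compound 3 `COc1cc(/C=C/C(=O)c2cccc(N)c2)ccc1O`: 12.3 ug/mL

All three were tested in a functional assay on SiHa cells (Homo sapiens) for inhibition; a lower number here means a stronger inhibitor, a higher number a weaker inhibitor. Compound 1 stands in the middle of this small set, with compound 2 giving a lower number and compound 3 a higher one. The unmeasured compound 4 `COc1cc(/C=C/C(=O)c2cccc(NC(=O)c3ccc(Cl)c(Cl)c3)c2)ccc1O` differs from compound 1 in one place: chloro in place of hydrogen on an aromatic carbon, which turns 4-chlorophenyl into 3,4-dichlorophenyl.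

For the measured compounds named here, three measured steps bear on this, all at the same nitrogen. Exchanging the aryl group gives a 3.0-fold lower number from compound 1 to compound 2 (0.48 log units; beyond the scatter), a modest change. Removing the acyl group gives a 5.3-fold higher number from compound 1 to compound 3 (0.73 log units; beyond the scatter), also modest, and a 16-fold higher number from compound 2 to compound 3 (1.21 log units; beyond the scatter), which is large. Going by the values given here, each of these replaces a whole group, and none adds a single chloro, so the change in compound 4 has no direct measured precedent. As a much smaller edit, it is expected to give no step beyond the scatter, in either direction. The estimated step is a 1.2-fold lower number from compound 1 to compound 4 (0.06 log units; within the scatter). For compound 4 the expected value is 2 ug/mL, with an estimated range from 0.8 ug/mL to 5.5 ug/mL.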

Compound 4, half-maximal inhibitory concentration: 25.3 ug/mL
Estimate against measurement, compound 4: 13-fold (1.10 log units) below; the whole stated range lies below it.
By their numbers in this assay, from the lowest: compound 2; then compound 1; then compound 3; then compound 4.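

In this assay, one added chloro on an aromatic carbon of the acyl group proves to be no minor edit: turning 4-chlorophenyl into 3,4-dichlorophenyl gives an 11-fold higher number from compound 1 to compound 4 (1.04 log units; beyond the scatter). Acylating the nitrogen therefore does not lower the number in every case, as it did with the 4-chlorophenyl and furan-2-yl amides: (3,4-dichlorophenyl)carbonyl in place of hydrogen gives a 2.1-fold higher number from compound 3 to compound 4 (0.31 log units; beyond the scatter). Against the furan-2-yl amide, the change of group on the carbonyl carbon gives a 33-fold higher number from compound 2 to compound 4 (1.52 log units; beyond the scatter), so this position responds strongly to small and large changes alike.

Nothing available here explains why a single chloro has so large an effect. As far as these compounds go, it also remains open whether this step is specific to chloro, since a methyl or a methoxy group on the same carbon could give a different result.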